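A few compounds are considered here, and "the series" means these few. Any claim that something is new, unique, unknown or untested is made for them only; others in the source may bear on it.

Values in a toxicity assay on Huh-7.5 cells (Homo sapiens) for inhibition, read by MTT assay, with a stated time of 96 h (on this read-out lower numbers stand for higher toxicity in this test and higher numbers for lower toxicity in this test), so far
compound 1 `CCC(=O)Nc1cc(C(=O)Nc2ccc(N3CCN(C)CC3)cc2)ccc1OC` gives > 200000 nM
compound 2 `CN1CCN(Cc2ccc(NC(=O)c3ccc(OCCCCCCl)c([N+](=O)[O-])c3)cc2C(F)(F)F)CC1` gives 2140 nM
compound 3 `CN1CCN(Cc2ccc(NC(=O)c3ccc(OCCCCl)c(C(F)(F)F)c3)cc2C(F)(F)F)CC1` gives 13400 nM

Compound 1 sits at > 200000 nM as a limit of the assay and not a number.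

Of the two true numbers, compound 2 stands lowest at 2140 nM and compound 3 is higher at 13400 nM with a gap beyond the usual scatter. Compound 4 `CC(C)Oc1ccc(C(=O)Nc2ccc(CN3CCN(C)CC3)c(C(F)(F)F)c2)cc1[N+](=O)[O-]` is not yet measured. Against compound 2 it carries isopropyl in place of 5-chloropentyl on an oxygen on an aromatic ring. Going by the values given here, no single-change step has been measured in this assay for this set, so the expectation is loose. Among the compounds with values here, the one guide is compound 3 at 13400 nM since its group on that oxygen also differs from 5-chloropentyl, though it differs from compound 2 elsewhere too. A step beyond the scatter toward a higher number, meaning lower toxicity in this test, is expected, with an estimated size of a 5.6-fold higher number from compound 2 to compound 4 (0.75 log units; beyond the scatter) as a rough figure. For compound 4 the estimated value is 12000 nM (expected range 4000 nM to 40000 nM).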

Compound 4, half-maximal cytotoxic concentration: 3500 nM
Compound 4: the middle estimate sits 3.4-fold (0.54 log units) above what was measured; measured number outside the range, below it.
By their numbers in this assay, from the lowest: compounds 2 and 4 (each within the scatter of the next); then compound 3. At a limit, above all of these: compound 1.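

Isopropyl in place of 5-chloropentyl on an oxygen on an aromatic ring gives a 1.6-fold higher number from compound 2 to compound 4 (0.21 log units; within the scatter) in this assay. Going by these compounds alone, this is the first single-change reading at this place, and on the core of compound 2 the two groups cannot be told apart in this test, so the chlorine-bearing chain is not needed for the toxicity seen with this pair. No measured property shown here bears on this step.

Open is how this oxygen behaves with a carboxylic acid or an amine at the end of a longer chain, since both groups shown here carry neither. Also open, as far as these compounds go, is whether the same exchange reads alike on the core of compound 3, which differs from compound 2 in more than one place.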